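Replacing the dimethylamino group with methoxymethyl on the fused core

This account rests on a few compounds, and the source may have more. Where it says the series, first, only, none or still open, it means among the compounds named here.

Compound 1 `COc1c(F)c(N)c2c(=O)cc(-c3ccc(N)c(F)c3)oc2c1F`, in a functional assay on HeLa cells (Homo sapiens) for cytotoxicity, read by neutral red uptake, with a stated time of 3 days; a higher number here means a weaker inhibitor, a lower number a stronger inhibitor: 34000 nM
Compound 2 `CN(C)c1c(F)c(N)c2c(=O)cc(-c3ccc(N)c(F)c3)oc2c1F`, in this assay: > 100000 nM, a limit of the assay rather than a number

Compound 2 stands at the limit (the limit of > 100000 nM in this assay, at which 1 of the 2 values shown sits); nothing more is known of it than that. Among the measured compounds shown here, the only measured step, an at least 2.9-fold higher number from compound 1 to compound 2 (0.46 log units; beyond the scatter), went from a methoxy group to a dimethylamino group on the same aromatic carbon and weakened the inhibition.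

Compound 3 `COCc1c(F)c(N)c2c(=O)cc(-c3ccc(N)c(F)c3)oc2c1F` is not yet measured. It differs from compound 2 by methoxymethyl in place of dimethylamino on an aromatic carbon. For the measured compounds named here, the change returns an oxygen-containing group of the same size as the methoxy of compound 1 to that position, so the step from compound 1 to compound 2 is the only guide, and a move back toward the number of compound 1 is expected, though its size is uncertain. Compound 3 is therefore expected to give 50000 nM in this assay, within 15000 nM to 200000 nM. Such an estimate would mean a step of an at least 2.0-fold lower number from compound 2 to compound 3 (0.30 log units; that floor lies within the scatter).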

Compound 3, half-maximal inhibitory concentration: > 100000 nM
Compound 3 was reported as a limit; the forecaster's own chance of this, stated with the estimate: 35%; at least 2.0-fold (0.30 log units) between middle value and limit.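

Compound 3 is reported only as a limit, the same one that compound 2 reached: the limit of > 100000 nM in this assay, at which 2 of the 3 values shown sit. The step between these two compounds cannot be read, so the result does not separate methoxymethyl from dimethylamino at this aromatic carbon. Methoxymethyl in place of methoxy gives an at least 2.9-fold higher number from compound 1 to compound 3 (0.46 log units; beyond the scatter), so the weaker reading seen with dimethylamino is not confined to that group, and among the three groups shown only methoxy gives a number rather than a limit.

The compounds shown leave open how far the true values of compound 2 and compound 3 lie from the limit of the assay. They also leave open whether a hydroxyl, an ethoxy group or a plain hydrogen on this carbon would give a measured number, and how it would compare with compound 1.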